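The source may report more compounds than this note shows. Statements on the series, on what has been measured and on what is new or still open speak of the compounds shown alone.

Series notes. In a functional assay on the whole organism for inhibition, with Mus musculus as the target, with a stated time of 6 h, at a dose of 50 mg/kg by the oral route (on this read-out higher numbers stand for more inhibition at the one dose given (going by the name of the read-out) and lower numbers for less inhibition), compound 1 `Cc1ccc(-c2c(S(=O)(=O)c3ccccc3)cnc3cc(C)nn23)cc1` gives 8.7%, compound 2 `Cc1cc2ncc(S(=O)(=O)c3ccccc3)c(-c3ccc(Br)cc3)n2n1` gives 0%, and compound 3 `Cc1ccc(-c2c(S(=O)(=O)c3ccccc3)cnc3c(Br)c(-c4ccccc4)nn23)cc1` gives 6.6%. Compound 3 thus holds the second highest of the three numbers, but its gaps to compound 1 and to compound 2 both sit within the scatter, so the three numbers cannot be ranked. Compound 4 `Cc1ccc(-c2c(S(=O)(=O)c3ccccc3)cnc3cc(-c4ccccc4)nn23)cc1` differs from compound 3 by hydrogen in place of bromo on an aromatic carbon. For the measured compounds named here, no measured pair tests removal of a bromo at this place. Going by the values given here, the one measured step, a number 8.7 percentage points lower from compound 1 to compound 2 (within the scatter), concerns a bromo elsewhere and stays within the scatter. Among the compounds with values here, with every number so far near the low end of this assay, no step beyond the scatter is expected for a number 1.4 percentage points higher from compound 3 to compound 4 (within the scatter). Compound 4 is therefore estimated at 8%, in the range 0% to 20%.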

Compound 4, a percentage reported as inhibition, in the whole organism at one dose (the size of the read-out at that dose, not a potency): 15.5%
Estimate against measurement, compound 4: 7.5 percentage points below; the range from low to high includes it.
By their numbers in this assay, from the lowest: compounds 2, 3, 1 and 4 (each within the scatter of the next, the first and the last beyond it).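

Taking the bromo off the aromatic carbon next to the ring atom that bears a phenyl group gives a number 8.9 percentage points higher from compound 3 to compound 4 (within the scatter) in this assay and so does not separate the two compounds. At the phenyl-bearing carbon, a number 6.8 percentage points higher from compound 1 to compound 4 (within the scatter) likewise does not separate phenyl from methyl. No measurement on hand explains either number.

From the compounds shown here alone, it stays open whether an amine or a carboxylic acid on the bromo-bearing carbon would move the number beyond the scatter. The same question holds for a longer chain in place of the phenyl.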